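The source may hold more compounds than are shown below. What is called first, only, known or untested is meant among the compounds shown, and "the series" means these compounds.

In a functional assay on HeLa cells (Homo sapiens) for antiproliferative activity, read by MTT assay, with a stated time of 48 h (on this read-out lower numbers stand for stronger inhibition and higher numbers for weaker inhibition), compound 1 (`Cc1ccc2nc(NC(c3cn(-c4ccccc4)nc3-c3cccc(Cl)c3)c3c(O)ccc4ccccc34)sc2c1`) gives 9430 nM and compound 2 (`Cc1ccc(-c2nn(-c3ccccc3)cc2C(Nc2nc3cc(C)c(C)cc3s2)c2c(O)ccc3ccccc23)cc1`) gives 17800 nM while compound 3 (`COc1ccc2nc(NC(c3cn(-c4ccccc4)nc3-c3ccc(Cl)cc3)c3c(O)ccc4ccccc34)sc2c1`) gives 5200 nM as the starting point here. The numbers for compound 3 and compound 1 lie within the usual scatter of each other, so these two cannot be told apart. The number for compound 3 is lower than that for compound 2, and this gap lies beyond the scatter. Compound 4 (`COc1ccc2nc(NC(c3cn(-c4ccccc4)nc3-c3cccc(I)c3)c3c(O)ccc4ccccc34)sc2c1`) has not been measured yet and carries 3-iodophenyl in place of 4-chlorophenyl on an aromatic carbon. Among the measured compounds shown here, no two measured compounds differ in one place only, so the data do not show what a swap of this kind does. A step beyond the scatter is therefore not expected, and no firm direction can be named. In this assay the expected change is a 1.3-fold higher number from compound 3 to compound 4 (0.10 log units; within the scatter) which stays within the scatter. The estimated value for compound 4 is 6500 nM (expected range 2800 nM to 15000 nM).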

Compound 4, half-maximal inhibitory concentration: 6240 nM
For compound 4 the middle estimate is 1.0-fold (0.02 log units) above the measured one; the measured number falls inside the stated range.
By their numbers in this assay, from the lowest: compounds 3, 4, 1 and 2 (each within the scatter of the next, the first and the last beyond it).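

In this assay, among the compounds shown here, compounds 3 and 4 form the first pair that differs in one place, and the swap gives a 1.2-fold higher number from compound 3 to compound 4 (0.08 log units; within the scatter) and so leaves the two compounds indistinguishable. On this aromatic carbon of the five-membered aromatic ring with 2 nitrogen, 3-iodophenyl is therefore tolerated as well as 4-chlorophenyl, even though the swap changes both the halogen and its place on the phenyl ring. Nothing available here offers an explanation for this result.

This single pair cannot separate the effect of exchanging chlorine for iodine from that of moving the halogen, and those two effects could be small or could offset each other; 4-iodophenyl would separate them. On these data alone, it also remains open whether a different kind of group here, such as a pyridine ring or a phenyl ring carrying an amine or a carboxylic acid, would shift the number beyond the scatter.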